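Azo series: naphthalen-1-yl replacing phenyl, alkyne linker retained

The source may report more compounds than this note shows. Statements on the series, on what has been measured and on what is new or still open speak of the compounds shown alone.

Going by the values given here, compound 1 `O=C(O)C1CCCN(CCCC#Cc2cccc(N=Nc3ccccc3)c2)C1` stands highest of the three numbers so far: in a physicochemical assay for pharmacokinetics, read by spectrophotometry, in phosphate buffer, at pH 7.4, tested at 20 uM (on this read-out lower numbers stand for a shorter-lived compound and higher numbers for a longer-lived compound), compound 1 gives 360 h. Compound 2 `O=C(O)C1CCCN(CCC=Cc2cccc(N=Nc3cccc4ccccc34)c2)C1` gives 22 h and compound 3 `O=C(O)C1CCCN(CCCC=Cc2cccc(N=Nc3cccc4ccccc34)c2)C1` gives 11 h; the step of a 2.0-fold lower number from compound 2 to compound 3 (0.30 log units; within the scatter) concerns the chain only. Compound 4 `O=C(O)C1CCCN(CCCC#Cc2cccc(N=Nc3cccc4ccccc34)c2)C1` is compound 1 with naphthalen-1-yl in place of phenyl on a double-bonded nitrogen. Among the compounds with values here, no measured step isolates this change; compounds 2 and 3 carry the naphthalen-1-yl group but differ from compound 1 in the linker as well, so their much lower numbers only hint at the direction. A sizeable drop is therefore expected, a 12-fold lower number from compound 1 to compound 4 (1.08 log units; beyond the scatter), though its size is uncertain. Compound 4 is estimated at 30 h, within a range of 8 h to 120 h.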

Compound 4, half-life: 43.2 h
Compound 4: middle estimate off by 1.4-fold (0.16 log units), on the low side; low and high end bracket the measured number.
By their numbers in this assay, from the lowest: compounds 3, 2 and 4 (each within the scatter of the next, the first and the last beyond it); then compound 1.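

With the alkyne linker held constant, the swap to naphthalen-1-yl on a double-bonded nitrogen now has a step of its own in this assay (an 8.3-fold lower number from compound 1 to compound 4 (0.92 log units; beyond the scatter)). Going by these compounds alone, in compound 2 and compound 3 this group came with a different linker, so this is the first reading of the change alone, and it lies beyond the scatter. No evidence at hand bears on what lies behind this step.

Open, as far as these compounds go, is whether naphthalen-2-yl or a methoxy-substituted phenyl on the same nitrogen would give a similar number. Also open, from the compounds shown here alone, is whether the step holds with an alkene linker, which would take a phenyl partner for compound 2 or compound 3.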